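Cytotoxicity on rat cells: an ester-to-amide switch in a bridged core

This account rests on a few compounds, and the source may have more. Where it says the series, first, only, none or still open, it means among the compounds named here.

Measured compounds in an ADME assay on L6 cells (Rattus norvegicus) for cytotoxicity, read by resazurin assay, with a stated time of 72 h; on this read-out higher numbers stand for weaker inhibition and lower numbers for stronger inhibition:
compound 1 `O=C(CN1CCCC1)OC1CC2(N3CCCCC3)CC(c3ccccc3)C1C(c1ccccc1)C2`: 16400 nM
compound 2 `CN(C)C12CC(OC(=O)CN3CCCC3)C(C(c3ccccc3)C1)C(c1ccccc1)C2`: 32700 nM
compound 3 `CN1CCN(CCC(=O)N2CCC3(N(C)C)CC(c4ccccc4)C2C(c2ccccc2)C3)CC1`: 128000 nM

Compound 1 holds the lowest of the three numbers; compound 2 lies closest to it, and compound 3 furthest away, beyond the scatter. Compound 4 `CN1CCN(CCC(=O)NC2CC3(N4CCCCC4)CC(c4ccccc4)C2C(c2ccccc2)C3)CC1` differs from compound 1 in one place: ((2-(4-methylpiperazin-1-yl)ethyl)carbonyl)amino in place of (((pyrrolidin-1-yl)methyl)carbonyl)oxy on a saturated ring carbon. Among the measured compounds shown here, only one measured step exists, a 2.0-fold higher number from compound 1 to compound 2 (0.30 log units; within the scatter), and it concerns a different group, so it does not bear directly on this change. For the measured compounds named here, no measured pair isolates the change itself. Compound 3, which also carries the 4-methylpiperazinyl ethyl carbonyl group, shows a higher number than compound 2, which is the only hint available. For compound 4 a higher number than compound 1 is therefore expected, amounting to a 3.0-fold higher number from compound 1 to compound 4 (0.48 log units; beyond the scatter). The estimate for compound 4 is 50000 nM, within a range from 16000 nM to 160000 nM.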

Compound 4, half-maximal inhibitory concentration: 61100 nM
Compound 4: the middle estimate sits 1.2-fold (0.09 log units) below what was measured, within the range that was stated.
By their numbers in this assay, from the lowest: compounds 1, 2 and 4 (each within the scatter of the next, the first and the last beyond it); then compound 3.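

In this assay, ((2-(4-methylpiperazin-1-yl)ethyl)carbonyl)amino in place of (((pyrrolidin-1-yl)methyl)carbonyl)oxy gives a 3.7-fold higher number from compound 1 to compound 4 (0.57 log units; beyond the scatter) on this saturated ring carbon. This shows that the read-out responds to this change, while the earlier step concerned the piperidin-1-yl group and stayed within the scatter. No measurement given here accounts for the step.

The change alters the linking atom, the chain and the ring together, so the compounds shown do not separate their contributions. They also leave open how a simple primary amine or hydroxyl group on this carbon would read.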